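From 3,3-dimethyloxetan-2-yl to oxan-3-yl

A few compounds are considered here, and "the series" means these few. Any claim that something is new, unique, unknown or untested is made for them only; others in the source may bear on it.

Three compounds measured so far in an in vitro ADME assay on microsomes from liver (Homo sapiens) for metabolic stability, read by HPLC (on this read-out higher numbers stand for fast clearance and lower numbers for slow clearance), are:
Compound 1 `NC(=O)[C@@H](CCC(F)(F)F)N(CC1COC1)S(=O)(=O)c1ccc(Cl)cc1` gives 16.9 mL/min/kg
Compound 2 `CC1(C)CO[C@@H]1CN([C@H](CCC(F)(F)F)C(N)=O)S(=O)(=O)c1ccc(Cl)cc1` gives > 293 mL/min/kg (a limit of the assay, not a number)
Compound 3 `CC1(C)CO[C@H]1CN([C@H](CCC(F)(F)F)C(N)=O)S(=O)(=O)c1ccc(Cl)cc1` gives 262 mL/min/kg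

Compound 3 at 262 mL/min/kg holds the higher of the two actual numbers, well clear of compound 1. Compound 4 `NC(=O)[C@@H](CCC(F)(F)F)N(C[C@@H]1CCCOC1)S(=O)(=O)c1ccc(Cl)cc1` keeps the shared core and differs from compound 3 in one group (oxan-3-yl in place of 3,3-dimethyloxetan-2-yl on a saturated chain carbon bound to a sulfonamide nitrogen), with oxan-3-yl in place of 3,3-dimethyloxetan-2-yl on a saturated chain carbon bound to a sulfonamide nitrogen.

Going by the values given here, no measured step makes this exchange. The closest evidence is the pair of large steps that bring in 3,3-dimethyloxetan-2-yl in place of oxetan-3-yl (an at least 17-fold higher number from compound 1 to compound 2 (1.23 log units; beyond the scatter) and a 16-fold higher number from compound 1 to compound 3 (1.19 log units; beyond the scatter)). Both drawn configurations of that group sit high, and the floor of the step between them (an at least 1.1-fold lower number from compound 2 to compound 3 (0.04 log units; that floor lies within the scatter)) lies within the scatter. With that group gone, clearance in this assay is expected to fall. Yet oxan-3-yl is not the oxetan-3-yl of compound 1 (16.9 mL/min/kg), so only part of that gap is expected to close. The estimated step is a clear drop (a 2.9-fold lower number from compound 3 to compound 4 (0.46 log units; beyond the scatter)) beyond the scatter. For compound 4 the expected clearance is 90 mL/min/kg (estimated range 30 mL/min/kg to 250 mL/min/kg).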

Compound 4, clearance: 136 mL/min/kg
The estimate for compound 4 lay 1.5-fold (0.18 log units) below the measured number; measured number inside the range.
By their numbers in this assay, from the lowest: compound 1; then compounds 4 and 3 (each within the scatter of the next). At a limit, above all of these: compound 2.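

In this assay, the exchange at this place, on a saturated chain carbon bound to a sulfonamide nitrogen, shows that losing 3,3-dimethyloxetan-2-yl is not enough to return to the level of compound 1 (an 8.0-fold higher number from compound 1 to compound 4 (0.91 log units; beyond the scatter)), while the step against the drawn configuration in compound 3 (a 1.9-fold lower number from compound 3 to compound 4 (0.28 log units; within the scatter)) leaves the two compounds indistinguishable. Among the four compounds, only compound 1, with oxetan-3-yl, stands apart from the rest, so oxan-3-yl, with the same atoms as 3,3-dimethyloxetan-2-yl but a six-membered ring, does not share the reading of oxetan-3-yl. The step from the other configuration (an at least 2.1-fold lower number from compound 2 to compound 4 (0.33 log units; beyond the scatter)) lies beyond the scatter, but it is only a floor, as compound 2 gave no number and stands at a limit of the assay: the limit of > 293 mL/min/kg in this assay, at which 1 of the 4 values shown sits.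

The compounds shown leave open whether the low reading of compound 1 extends to other small cyclic ethers at this place, such as oxolan-3-yl or 3-methyloxetan-3-yl. They also leave open how oxan-4-yl or the opposite configuration of oxan-3-yl would read in this assay.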